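This account rests on a few compounds, and the source may have more. Where it says the series, first, only, none or still open, it means among the compounds named here.

Of the compounds shown here, three sharing one core have been tested in a functional assay on SK-OV-3 cells (Homo sapiens) for antiproliferative activity, read by MTT assay, with a stated time of 24 h; a higher number here means a weaker inhibitor, a lower number a stronger inhibitor. Compound 1 `COc1ccc(C(=O)/C=C/c2ccc(N(c3ccccc3)c3ccccc3)cc2)c2c1C=CC(C)(C)O2` reaches only the limit of > 10000 nM in this assay. Compound 3 `COc1ccc(C(=O)/C=C/c2cccc3ccccc23)c2c1C=CC(C)(C)O2` likewise stops at the limit of > 10000 nM. Compound 2 `COc1ccc(/C=C/C(=O)c2ccc(OC)c3c2OC(C)(C)C=C3)cn1` also sits at > 10000 nM, which is a limit of the assay and not a number, so its standing rests on the limit of > 10000 nM in this assay, at which 3 of the 3 values shown sit, alone. Compound 4 `COc1ccc(C(=O)/C=C/c2cc(Cl)ccc2O)c2c1C=CC(C)(C)O2` has not yet been measured and differs from compound 2 in one place: 5-chloro-2-hydroxyphenyl in place of 6-methoxypyridin-3-yl on a double-bonded chain carbon bound to a double-bonded chain carbon. Among the compounds with values here, no measured pair shows the effect of such a change, and every value so far is a limit, so the step expected in a step that the limit leaves unreadable from compound 2 to compound 4 is none beyond the scatter. Compound 4 is therefore estimated at 15000 nM, within a range from 3000 nM to 60000 nM.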

Compound 4, half-maximal inhibitory concentration: 6270 nM
For compound 4 the middle estimate is 2.4-fold (0.38 log units) above the measured one; measured number inside the range.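

Within the data shown here, compound 4 is the first compound here to give a measured number rather than a limit in this assay, so a group at this place on the shared core can bring a readable value. The change gives an at least 1.5-fold lower number from compound 2 to compound 4 (0.20 log units; that floor lies within the scatter). That floor alone does not establish a gain, and only a floor can be read: the limit of > 10000 nM in this assay, at which 3 of the 4 values shown sit.

Whether the chlorine or the hydroxy group of 5-chloro-2-hydroxyphenyl accounts for the readable value remains open. So does the outcome with an amine in place of that hydroxy group.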